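Swapping Methyl for Trifluoromethoxy in a Clearance Series

The compounds below may be only part of what the source reports. "The series", "measured", "known", "first", "only" and "open" are said of these compounds alone.

In an ADME assay on microsomes from liver (Homo sapiens) for metabolic stability (on this read-out higher numbers stand for fast clearance and lower numbers for slow clearance), compound 2 `Cc1ccc([C@H](C)NC(=O)Cn2nnc3ccccc3c2=O)c(F)c1` gives 28 mL/min/kg, and compound 3 `COc1cc(C)ccc1[C@H](C)NC(=O)Cn1nnc2ccccc2c1=O` gives 30 mL/min/kg, so the two lie within the scatter of each other. Compound 1 `C[C@H](NC(=O)Cn1nnc2ccccc2c1=O)c1ccc(Cl)cc1` gives only a limit, < 9.9 mL/min/kg. Compound 4 `C[C@H](NC(=O)Cn1nnc2ccccc2c1=O)c1ccc(OC(F)(F)F)cc1F` carries trifluoromethoxy in place of methyl on an aromatic carbon of compound 2 (trifluoromethoxy in place of methyl on an aromatic carbon).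

Within the data shown here, two measured steps bear on this change. The more useful is an at least 2.8-fold higher number from compound 1 to compound 2 (0.45 log units; beyond the scatter), a change that brought in the methyl group together with a fluoro group. This single step cannot separate the two groups, and compound 4 keeps the fluoro group while losing the methyl. The other is a 1.1-fold higher number from compound 2 to compound 3 (0.03 log units; within the scatter), which swaps fluoro for methoxy and leaves the methyl untouched, so it says little here. A modest move towards a lower number is therefore expected, probably not beyond the scatter. The estimated step runs a 1.6-fold lower number from compound 2 to compound 4 (0.22 log units; within the scatter). For compound 4 the estimated clearance is 17 mL/min/kg, with an expected range of 9 mL/min/kg to 35 mL/min/kg.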

Compound 4, clearance: < 9.9 mL/min/kg
Compound 4 ended at the assay's limit; the forecaster's own chance of this, stated with the estimate: 20%; at least 1.7-fold (0.23 log units) between middle value and limit.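

In this assay, trifluoromethoxy in place of methyl on the aromatic carbon para to a large group gives an at least 2.8-fold lower number from compound 2 to compound 4 (0.45 log units; beyond the scatter). The fluoro group stays in place across this step, so the change at this one position is enough to move the number beyond the scatter, which the earlier step from a 4-chlorophenyl group could not show because it altered two groups at once. Compound 4 gives a limit of the assay rather than a number, so the step is a minimum and its true size stays unknown: the limit of < 9.9 mL/min/kg in this assay, at which 2 of the 4 values shown sit.

On these data alone, how low the clearance of compound 4 really lies remains open. As far as these compounds go, it is also open whether a nitrile, an amine or a longer chain at this position would give a number as low, and whether trifluoromethoxy would do so without the fluoro group.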